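This account rests on a few compounds, and the source may have more. Where it says the series, first, only, none or still open, it means among the compounds named here.

Of the compounds shown here, three of one shared core have been measured in a functional assay on RPMI-8226 cells (Homo sapiens) for cytotoxicity, read by sulforhodamine B assay, with a stated time of 48 h; on this read-out lower numbers stand for stronger inhibition of growth and higher numbers for weaker inhibition of growth. Compound 1 `Nc1nc(Cl)c2ncn(Cc3ccccc3CCl)c2n1` gives only a limit, > 100000 nM; this is the limit of > 100000 nM in this assay, at which 1 of the 3 values shown sits, and not a number. Compound 3 `ClCc1ccccc1Cn1cnc2nc(Cl)nc(Cl)c21` gives 630 nM. Compound 2 `ClCc1cccc(Cn2cnc3nc(Cl)nc(Cl)c32)c1` gives 4160 nM, which is the higher of the two numbers; the step from it to compound 3 lies beyond the usual scatter, so compound 2 inhibits growth less strongly than compound 3 on this read-out.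

The next compound, compound 4 `ClCc1cccc(Cn2cnc3ncnc(Cl)c32)c1`, differs from compound 2 in one place only: hydrogen in place of chloro on an aromatic carbon. The chloro that leaves sits on an aromatic carbon of a six-membered aromatic ring with two nitrogen, between two ring nitrogen atoms, and a hydrogen takes its place. Going by the values given here, no measured pair in this set differs in exactly this way, so no measured step gives the size of the change directly. Among the compounds with values here, compound 1, the one compound in which that carbon carries something other than chloro, gives only the limit noted above.

On this basis compound 4 is expected to give a weaker growth inhibition than compound 2, with a step of a 3.6-fold higher number from compound 2 to compound 4 (0.56 log units; beyond the scatter) in this assay. The estimate for compound 4 is 15000 nM, expected to fall between 3000 nM and 100000 nM.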

Compound 4, concentration for total growth inhibition: 34700 nM
The estimate for compound 4 lay 2.3-fold (0.36 log units) below the measured number, within the range that was stated.
By their numbers in this assay, from the lowest: compound 3; then compound 2; then compound 4. At a limit, above all of these: compound 1.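

In this assay, going by these compounds alone, compound 2 and compound 4 form the first measured pair that differs in one place, and so they give this change a size: hydrogen in place of chloro on the aromatic carbon between two ring nitrogen atoms brings an 8.3-fold higher number from compound 2 to compound 4 (0.92 log units; beyond the scatter). With the rest of compound 2 held fixed, then, the chloro at this place goes with stronger inhibition of growth than hydrogen does, and the step is large enough to be read as a real loss rather than as noise between repeated measurements. Compound 1 carries an amino group on that carbon, but it differs from compound 2 in more than one place and gives a limit and not a number, so it adds no size for any change at this position: the limit of > 100000 nM in this assay, at which 1 of the 4 values shown sits.

Whether the loss is the same size in the setting of compound 3 stays open, as this is a single pair and compound 3 has no hydrogen counterpart among the compounds shown. Also open, from the compounds shown here alone, is how a fluoro, methyl or methoxy group on this carbon would compare with chloro and hydrogen, and whether the remaining chloro on the ring matters to the same degree.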